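Thiazolyl in Place of Fluorophenyl: Cytotoxicity Outlook

The compounds below may be only part of what the source reports. "The series", "measured", "known", "first", "only" and "open" are said of these compounds alone.

Compound 1 `CCOC(=O)c1cn(-c2ccccc2F)nc1CC(C)C`: > 100000 nM
Compound 2 `CCOC(=O)c1cn(-c2cccc(OC)c2)nc1CC(C)C`: 70500 nM
Compound 3 `CC(C)Cc1nn(-c2nccs2)cc1C(=O)NCc1ccc(F)cc1F`: 83600 nM

Of the compounds shown here, three have been tested in a toxicity assay on HepG2 2.2.15 cells (Homo sapiens) for cytotoxicity, read by CCK-8 assay, with a stated time of 8 days; on this read-out lower numbers stand for higher toxicity in this test and higher numbers for lower toxicity in this test. Compound 1 gives only a limit of the assay, > 100000 nM, as the limit of > 100000 nM in this assay, at which 1 of the 3 values shown sits, shows, so its exact place cannot be told. Compound 2 gives 70500 nM and compound 3 gives 83600 nM in this assay ; these two lie within the scatter of each other.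

Compound 4 `CCOC(=O)c1cn(-c2nccs2)nc1CC(C)C` is not yet measured. It differs from compound 1 in one place: 1,3-thiazol-2-yl in place of 2-fluorophenyl on an aromatic nitrogen. Among the compounds with values here, no measured pair shows this change alone. Compound 3 carries the same 1,3-thiazol-2-yl group and gives 83600 nM in this assay . The step is therefore expected to be no larger than the scatter, without a clear direction, an at least 1.1-fold lower number from compound 1 to compound 4 (0.04 log units; that floor lies within the scatter). Compound 4 is estimated at 90000 nM, within 45000 nM to 180000 nM, and may again come back as a limit.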

Compound 4, half-maximal cytotoxic concentration: > 100000 nM
Compound 4: no number, only a limit; the forecaster's own chance of this, stated with the estimate: 45%; middle value at least 1.1-fold (0.04 log units) away from the limit.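

Compound 1 and compound 4 both stop at a limit of the assay, so no step can be read between them: the limit of > 100000 nM in this assay, at which 2 of the 4 values shown sit.

The compounds shown leave open whether 1,3-thiazol-2-yl in place of 2-fluorophenyl on an aromatic nitrogen shifts the read-out in this assay at all, and in which direction.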